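Adding an Aromatic Ester to Compound 1

This account rests on a few compounds, and the source may have more. Where it says the series, first, only, none or still open, it means among the compounds named here.

Within the data shown here, in a functional assay on Bel-7402 cells (Homo sapiens) for cytotoxicity, read by MTT assay, with a stated time of 72 h (on this read-out lower numbers stand for stronger inhibition and higher numbers for weaker inhibition), compound 1 `C=C1C(=O)[C@@]23C(=O)OC[C@]4(C(=O)CCC(C)(C)[C@H]4C=O)[C@@H]2CC[C@@H]1[C@H]3O` gives 5030 nM as the higher of the two numbers so far. Compound 2 `C=C1C(=O)[C@@]23C(=O)OC[C@]4(C(=O)CCC(C)(C)[C@H]4C=O)[C@@H]2CC[C@@H]1[C@H]3OC(=O)CC` gives 1650 nM with propanoyl on the oxygen. Compound 3 `C=C1C(=O)[C@@]23C(=O)OC[C@]4(C(=O)CCC(C)(C)[C@H]4C=O)[C@@H]2CC[C@@H]1[C@H]3OC(=O)c1ccc(C)cc1` is not yet measured and has (4-methylphenyl)carbonyl in place of hydrogen on an oxygen on a saturated carbon. Among the measured compounds shown here, only one measured step bears on this change, the modest 3.0-fold lower number from compound 1 to compound 2 (0.48 log units; beyond the scatter) beyond the scatter, so a similar fall is expected in this assay. This points to an expected 3.0-fold lower number from compound 1 to compound 3 (0.47 log units; beyond the scatter) as the likely size. The estimate for compound 3 is 1700 nM (expected range 600 nM to 4500 nM).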

Compound 3, half-maximal inhibitory concentration: 1540 nM
Compound 3: the middle estimate sits 1.1-fold (0.04 log units) above what was measured; low and high end bracket the measured number.
By their numbers in this assay, from the lowest: compounds 3 and 2 (each within the scatter of the next); then compound 1.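

In this assay, placing (4-methylphenyl)carbonyl on this oxygen gives a 3.3-fold lower number from compound 1 to compound 3 (0.51 log units; beyond the scatter). Replacing ethyl with 4-methylphenyl on the carbonyl carbon gives a 1.1-fold lower number from compound 2 to compound 3 (0.03 log units; within the scatter), so the aromatic ester and the propanoyl ester cannot be told apart here. No measurement on hand explains the change from the free hydroxy group.

Still open, from the compounds shown here alone, is whether a longer chain such as octanoyl, or an amine in place of the methyl on the aromatic ring, would change the number. A methyl ether on this oxygen would show whether the ester carbonyl matters.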